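The compounds below may be only part of what the source reports. "The series", "measured", "known", "first", "only" and "open" are said of these compounds alone.

Measured so far in a functional assay on COLO 205 cells (Homo sapiens) for inhibition, read by sulforhodamine B assay, with a stated time of 48 h, tested at 50 uM; a higher number here means more inhibition of growth at the concentration tested, a lower number less inhibition of growth:
compound 1 `COc1ccc2c(c1)C(=O)C(=O)N2CCCCCn1cc(COc2cc(=O)oc3ccccc23)nn1` gives 19%;
compound 2 `O=C1C(=O)N(CCCCCn2cc(COc3cc(=O)oc4ccccc34)nn2)c2ccc(Br)cc21` gives 39%;
compound 3 `O=C1C(=O)N(CCCn2cc(COc3cc(=O)oc4ccccc34)nn2)c2ccc(I)cc21` gives 56%.

Compound 3 stands highest of the three. Its gap to compound 2 lies beyond the scatter, and its larger gap to compound 1 lies beyond the scatter as well. Compound 4 `O=C1C(=O)N(CCCn2cc(COc3cc(=O)oc4ccccc34)nn2)c2ccc(Br)cc21` is the next compound: bromo in place of iodo on an aromatic carbon. Within the data shown here, the only measured single-point step, a number 20 percentage points higher from compound 1 to compound 2 (beyond the scatter), concerns bromo in place of methoxy and is a modest rise. Among the measured compounds shown here, no measured pair compares bromo with iodo, and compounds 2 and 3 differ in two places at once, so their two values alone show nothing clean about the halogen. The step of a number 8 percentage points lower from compound 3 to compound 4 (within the scatter) is therefore expected to be small, a slight fall at most. For compound 4 the estimate in this assay is 48%, with a range of 33% to 63%.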

Compound 4, percent growth inhibition at one concentration: 61%
Compound 4: the middle estimate sits 13 percentage points below what was measured; the measured number falls inside the stated range.
By their numbers in this assay, from the lowest: compound 1; then compound 2; then compounds 3 and 4 (each within the scatter of the next).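

In this assay, among these compounds, the halogen swap on the aromatic carbon gives a number 5 percentage points higher from compound 3 to compound 4 (within the scatter), the first clean comparison of two halogens. At this position, with this chain, bromo and iodo cannot be told apart, whereas replacing methoxy with bromo gave a step beyond the scatter, a number 20 percentage points higher from compound 1 to compound 2 (beyond the scatter), on a different chain. Nothing available explains why the two halogens read alike.

As far as these compounds go, whether fluoro, chloro or an amine at this position would read alike remains open. So does whether bromo and iodo also read alike on the other chain.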